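This account rests on a few compounds, and the source may have more. Where it says the series, first, only, none or still open, it means among the compounds named here.

Compound 3 `NCCCn1c(CCc2c[nH]c3ccccc23)nnc1Cc1ccc(Cl)c(Cl)c1`: 2380 nM
Compound 1 `Clc1ccc(Cn2c(CCc3c[nH]cn3)nnc2Cc2c[nH]c3ccccc23)cc1Cl`: > 10000 nM, a limit of the assay
Compound 2 `NCCCc1nnc(CCc2c[nH]c3ccccc23)n1Cc1ccccc1`: < 10000 nM, a limit of the assay

In an assay on cells for displacement of a labelled ligand from somatostatin receptor type 4 (Homo sapiens), with a stated time of 90 min (a lower number here means a stronger inhibitor, a higher number a weaker inhibitor), compound 3 gives 2380 nM, the only proper number among the three results shown. For compound 1 the assay reports only a limit, (the limit of > 10000 nM in this assay, at which 1 of the 3 values shown sits). For compound 2 likewise only a limit is reported, (the limit of < 10000 nM in this assay, at which 1 of the 3 values shown sits). Compound 4 `Clc1ccc(Cc2nnc(CCc3c[nH]c4ccccc34)n2CCCc2c[nH]cn2)cc1Cl` is compound 3 with one change: 1H-imidazol-4-yl in place of amino on a saturated chain carbon, three bonds along the chain from an aromatic nitrogen. Going by the values given here, no measured pair covers this change, so its effect is unknown. The step of a 1.5-fold higher number from compound 3 to compound 4 (0.17 log units; within the scatter) is expected to be small, at most a mild weakening beyond the scatter. Compound 4 is therefore estimated at 3500 nM, with a likely range from 1000 nM to 15000 nM.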

Compound 4, inhibition constant: 19 nM
For compound 4 the middle estimate is 180-fold (2.27 log units) above the measured one; the whole stated range lies above it.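

In this assay, going by these compounds alone, replacing 3-aminopropyl with 3-(1H-imidazol-4-yl)propyl gives a 130-fold lower number from compound 3 to compound 4 (2.10 log units; beyond the scatter), the first readable step at this position, and it shows that the group at the end of this chain strongly affects the result. Hydrogen-bond donors and acceptors are counted the same on both sides, so these counts do not separate the two groups. Nothing shown explains this gain. Going by these compounds, it remains open whether the 1H-imidazol-4-yl ring itself is required or whether a phenyl or pyridin-3-yl ring would serve equally well. The effect of a longer chain carrying the same ring is also unknown.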